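Octyloxy chain in place of ethoxy: cytotoxicity outlook

This account rests on a few compounds, and the source may have more. Where it says the series, first, only, none or still open, it means among the compounds named here.

The series shares one core, seen in compound 1 `Nc1nc(OCC(F)(F)F)c2ncn(/C=C3/CC3(CO)CO)c2n1` and compound 2 `CCOc1nc(N)nc2c1ncn2/C=C1/CC1(CO)CO`. In an ADME assay on Akata cells (Homo sapiens) for cytotoxicity, with a stated time of 7 days (a lower number here means that less compound is tolerated, a higher number that more compound is tolerated), compound 1 reaches only the assay limit of > 20000 nM. In this assay compound 2 likewise stops at the limit of > 20000 nM. For the measured compounds named here, the one measured step, a step that the two limits leave unreadable from compound 1 to compound 2, therefore cannot be read in size, since both ends sit at the limit of > 20000 nM in this assay, at which 2 of the 2 values shown sit.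

Compound 3 `CCCCCCCCOc1nc(N)nc2c1ncn2/C=C1/CC1(CO)CO` is the next case. It differs from compound 2 by hexyl in place of hydrogen on a saturated chain carbon, two bonds along the chain from an oxygen on an aromatic ring. Going by the values given here, no measured step bears on this change, so the expectation rests only on compound 2 standing at a limit in this assay. A move toward tolerance of less compound is expected, an at least 2.0-fold lower number from compound 2 to compound 3 (0.30 log units; that floor lies within the scatter), but with little grounding. Compound 3 is estimated in this assay at 10000 nM, within 2500 nM to 40000 nM.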

Compound 3, half-maximal cytotoxic concentration: > 20000 nM
Compound 3: only a limit was reported (the forecaster's own chance of this, stated with the estimate: 35%); middle value at least 2.0-fold (0.30 log units) from the limit.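

In this assay compound 3 stops at > 20000 nM, which is a limit, so no step among compound 1, compound 2 and compound 3 can be read in size: the limit of > 20000 nM in this assay, at which 3 of the 3 values shown sit.

Still open, on these data alone, is where the half-maximal cytotoxic concentration of each compound lies, and whether octyloxy in place of ethoxy changes it at all.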